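A few compounds are considered here, and "the series" means these few. Any claim that something is new, unique, unknown or untested is made for them only; others in the source may bear on it.

Measured compounds in the series:
- compound 1, `COc1cccc(NC(=O)COc2ccc3cc(/C=C4/SC(=O)NC4=O)ccc3c2)c1`: 1600 nM
- compound 2, `O=C(COc1ccc2cc(/C=C3/SC(=O)NC3=O)ccc2c1)Nc1ccccn1`: 17000 nM
- compound 3, `O=C(COc1ccc2cc(/C=C3/SC(=O)NC3=O)ccc2c1)Nc1ccc(F)cc1F`: 3900 nM

All three share one core and differ only in the group on the amide-type nitrogen. In an assay on isolated protein for inhibition of histone deacetylase 4 (Homo sapiens), with a stated time of 1 h (on this read-out lower numbers stand for stronger inhibition and higher numbers for weaker inhibition), compound 3 gives 3900 nM, which is the second highest of the three numbers: it is separated from compound 1 by a 2.4-fold higher number from compound 1 to compound 3 (0.39 log units; beyond the scatter) and from compound 2 by a 4.4-fold lower number from compound 2 to compound 3 (0.64 log units; beyond the scatter). Compound 4, `Cc1cc(NC(=O)COc2ccc3cc(/C=C4/SC(=O)NC4=O)ccc3c2)no1`, is not yet measured. It differs from compound 3 in one place: 5-methyl-1,2-oxazol-3-yl in place of 2,4-difluorophenyl on an amide-type nitrogen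

Among the compounds with values here, the steps that bear on this change are those that swap the aryl group on that nitrogen. Replacing a carbon-only ring with a ring holding nitrogen gave an 11-fold higher number from compound 1 to compound 2 (1.03 log units; beyond the scatter), and going back to a carbon-only ring gave a 4.4-fold lower number from compound 2 to compound 3 (0.64 log units; beyond the scatter). The group entering compound 4 likewise carries ring hetero atoms, so a weakening of modest size is expected in this assay, estimated as a 2.3-fold higher number from compound 3 to compound 4 (0.36 log units; beyond the scatter). Compound 4 is thus expected to give about 9000 nM, within 3000 nM to 27000 nM.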

Compound 4, half-maximal inhibitory concentration: 1700 nM
For compound 4 the middle estimate is 5.3-fold (0.72 log units) above the measured one; the whole stated range lies above it.
By their numbers in this assay, from the lowest: compounds 1 and 4 (each within the scatter of the next); then compound 3; then compound 2.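

In this assay, a ring with hetero atoms on the amide-type nitrogen does not by itself go with a higher number: 5-methyl-1,2-oxazol-3-yl in place of 2,4-difluorophenyl gives a 2.3-fold lower number from compound 3 to compound 4 (0.36 log units; beyond the scatter), and in place of pyridin-2-yl it gives a 10-fold lower number from compound 2 to compound 4 (1.00 log units; beyond the scatter). In place of 3-methoxyphenyl it gives a 1.1-fold higher number from compound 1 to compound 4 (0.03 log units; within the scatter), so compound 4 stands level with compound 1 and the high number of compound 2 does not extend to this hetero ring. Nothing measured here accounts for the difference between these two hetero rings.

Open, going by these compounds, is what the methyl group of compound 4 contributes, which an unsubstituted 1,2-oxazol-3-yl or an ethyl group in its place would test. Also open, on these data alone, is whether an aromatic ring is needed on the amide-type nitrogen at all, as against a cyclohexyl group or a short alkyl chain.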